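This account rests on a few compounds, and the source may have more. Where it says the series, first, only, none or still open, it means among the compounds named here.

Of the compounds shown here, three sharing one core have been tested in a functional assay on Raji cells (Homo sapiens) for cytotoxicity, with a stated time of 72 h; on this read-out higher numbers stand for an effect only at larger amounts of compound and lower numbers for an effect already at smaller amounts. Compound 1 `C=C[C@@](C)(/C=C/c1ccc(O)cc1)CCC(O)C(C)(C)O` gives only a limit of the assay, > 26000 nM. Compound 2 `C=C[C@@](C)(/C=C/c1ccc(O)cc1)CCC=O` likewise reaches only the limit, > 26000 nM. The step that the two limits leave unreadable from compound 1 to compound 2 therefore cannot be read. Compound 3 `C=C[C@@](C)(/C=C/c1ccc(O)c(CO)c1)CCC=C(C)C` also stands at the limit, > 26000 nM, so it cannot be ranked against the other two; what the numbers show is summed up by the limit of > 26000 nM in this assay, at which 3 of the 3 values shown sit.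

Compound 4 `C=C[C@@](C)(/C=C/c1ccc(O)c(/C=C/c2ccc(Cl)cc2)c1)CCC=C(C)C` differs from compound 3 by 2-(4-chlorophenyl)ethenyl in place of hydroxymethyl on an aromatic carbon. For the measured compounds named here, no measured step in this assay bears on this change: the only step recorded is unreadable, and every value gathered so far is a limit. There is thus no basis in the data for expecting the change to move the read-out in one direction or the other, nor for a particular size of step; the limit at which compound 3 sits leaves any size of step from compound 3 to compound 4 open. Taken as a rough guess, the step is estimated as an at least 2.1-fold lower number from compound 3 to compound 4 (0.33 log units; beyond the scatter). Compound 4 is estimated at 12000 nM, within a range from 2000 nM to 40000 nM, and a reading that is again only a limit remains quite possible.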

Compound 4, half-maximal effective concentration: > 26000 nM
Compound 4: no number, only a limit (the forecaster's own chance of this, stated with the estimate: 50%); middle value at least 2.1-fold (0.33 log units) from the limit.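

In this assay compound 4 gives > 26000 nM, again a limit and not a number. Compound 3 also sits at a limit, so the step between compound 3 and compound 4 cannot be read. The compounds shown leave open at what amount any of them would show an effect, and whether any of these changes moves the read-out at all: the limit of > 26000 nM in this assay, at which 4 of the 4 values shown sit.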